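Isopropyl to tert-Butyl on the Sulfonamide Nitrogen

A few compounds are considered here, and "the series" means these few. Any claim that something is new, unique, unknown or untested is made for them only; others in the source may bear on it.

Measured compounds:
Compound 1 `COCCN(C)S(=O)(=O)c1ccc(C)c(C#Cc2cc(Cl)ccc2OCC(=O)O)c1` — 4.1 nM
Compound 2 `Cc1ccc(S(=O)(=O)NC(C)C)cc1C#Cc1cc(Cl)ccc1OCC(=O)O` — 3.4 nM

In an assay on CHO cells for displacement of a labelled ligand from prostaglandin D2 receptor 2 (Homo sapiens), read by scintillation counting (on this read-out lower numbers stand for stronger inhibition and higher numbers for weaker inhibition), compound 1 gives 4.1 nM and compound 2 gives 3.4 nM. Compound 2 stands at the low end of these two numbers, but the step of a 1.2-fold lower number from compound 1 to compound 2 (0.08 log units; within the scatter) lies within the scatter, so the pair is not separated. Compound 3 `Cc1ccc(S(=O)(=O)NC(C)(C)C)cc1C#Cc1cc(Cl)ccc1OCC(=O)O` differs from compound 2 by methyl in place of hydrogen on a saturated chain carbon bound to two saturated chain carbons and a sulfonamide nitrogen, that is, isopropylamino to (tert-butyl)amino. Going by the values given here, the only step bearing on this sulfonamide substituent, from compound 1 to compound 2, changed little, so the expected step of a 1.2-fold higher number from compound 2 to compound 3 (0.07 log units; within the scatter) is none beyond the scatter. Compound 3 is therefore estimated at 4 nM, within 1.5 nM to 11 nM.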

Compound 3, inhibition constant: 5 nM
Estimate against measurement, compound 3: 1.3-fold (0.10 log units) below; the range from low to high includes it.
By their numbers in this assay, from the lowest: compounds 2, 1 and 3 (each within the scatter of the next).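

In this assay the change from isopropylamino to (tert-butyl)amino gives a 1.5-fold higher number from compound 2 to compound 3 (0.17 log units; within the scatter) and so shows that this carbon takes an added methyl without a step beyond the scatter. The step of a 1.2-fold higher number from compound 1 to compound 3 (0.09 log units; within the scatter) also stays within the scatter, so the (2-methoxyethyl)(methyl)amino, isopropylamino and (tert-butyl)amino groups on the sulfonyl sulfur are not separated from one another. No evidence at hand explains this result.

From the compounds shown here alone, it remains open whether a cyclic amine such as piperidine or morpholine on the sulfonyl sulfur, or a carboxylic acid on a longer chain at the sulfonamide nitrogen, would separate from these three compounds.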